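A few compounds are considered here, and "the series" means these few. Any claim that something is new, unique, unknown or untested is made for them only; others in the source may bear on it.

Measured so far in an assay on isolated protein for inhibition of disintegrin and metalloproteinase domain-containing protein 10 (Homo sapiens); a lower number here means a stronger inhibitor, a higher number a weaker inhibitor:
- compound 1 `O=C(NO)[C@H]1CC(CC(=O)N2CCCC2)CN[C@@H]1C(=O)N1CC[C@H](c2ccccc2)C1` gives 14 nM
- compound 2 `CN(C(=O)c1ccccc1)C1CN[C@H](C(=O)N2CC[C@H](c3ccccc3)C2)[C@@H](C(=O)NO)C1` gives 84 nM

Within the data shown here, compound 2 stands highest of these two numbers, and its only neighbour is compound 1, separated by a 6.0-fold higher number from compound 1 to compound 2 (0.78 log units; beyond the scatter). Compound 3 `O=C(NO)[C@H]1CC(OC(=O)N2CCCC2)CN[C@@H]1C(=O)N1CC[C@H](c2ccccc2)C1` arises from compound 2 through the change (((pyrrolidin-1-yl)carbonyl)oxy in place of benzoyl(methyl)amino on a saturated ring carbon). Among the measured compounds shown here, the one measured step that bears on it is a 6.0-fold higher number from compound 1 to compound 2 (0.78 log units; beyond the scatter), which brought in the same benzoyl(methyl)amino group that now leaves, replaced by a pyrrolidine-bearing carbonyl group resembling that of compound 1. The expected step is therefore a 4.2-fold lower number from compound 2 to compound 3 (0.62 log units; beyond the scatter). For compound 3 the estimated value in this assay is 20 nM, within the range 6 nM to 70 nM.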

Compound 3, half-maximal inhibitory concentration: 83 nM
Compound 3: the middle estimate sits 4.2-fold (0.62 log units) below what was measured, and the stated range ends below it.
By their numbers in this assay, from the lowest: compound 1; then compounds 3 and 2 (each within the scatter of the next).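

On this saturated ring carbon, swapping benzoyl(methyl)amino for ((pyrrolidin-1-yl)carbonyl)oxy leaves the reading in this assay unchanged, with a 1.0-fold lower number from compound 2 to compound 3 (0.01 log units; within the scatter), even though the aromatic ring is gone. Compound 1 and compound 3 both carry the pyrrolidine carbonyl and differ only in how it joins the ring, yet the change gives a 5.9-fold higher number from compound 1 to compound 3 (0.77 log units; beyond the scatter), so the pyrrolidine carbonyl alone does not set the number. No measurement here explains either result. From the compounds shown here alone, whether an amine nitrogen in that joining place, or a longer carbon chain, would behave like the methyl link of compound 1 stays open.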